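Swapping a phenyl for an acetyl-pyrazolyl in a urea amide series

A few compounds are considered here, and "the series" means these few. Any claim that something is new, unique, unknown or untested is made for them only; others in the source may bear on it.

Measured compounds:
- compound 1, `CNC(=O)N1CCCc2ccc(NC(=O)c3cccc(-c4ccccc4)c3)cc21`: 2.83%
- compound 2, `CNC(=O)N1CCCc2ccc(NC(=O)c3ccc(-c4ccncc4)cc3)cc21`: 37.6%
- compound 3, `CNC(=O)N1CCCc2ccc(NC(=O)c3ccc(-c4ccccn4)cc3)cc21`: 32%

In a functional assay on MV4-11 cells (Homo sapiens) for antiproliferative activity, with a stated time of 6 days, tested at 1.56 uM (a lower number here means a weaker effect, a higher number a stronger effect of the compound at the concentration tested), compound 1 gives 2.83%, the lowest of the three numbers; compound 3 lies higher by a margin beyond the scatter, and compound 2 lies higher still, also beyond the scatter. Among the compounds with values here, compounds 2 and 3 differ from compound 1 in more than one place, so no single step connects them to it; their values only show that the two pyridyl-bearing compounds sit well above compound 1.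

The unmeasured compound 4, `CNC(=O)N1CCCc2ccc(NC(=O)c3cccc(-c4ccn(C(C)=O)n4)c3)cc21`, differs from compound 1 in one place: 1-acetyl-1H-pyrazol-3-yl in place of phenyl on an aromatic carbon. Within the data shown here, the only measured step, a number 5.6 percentage points lower from compound 2 to compound 3 (within the scatter), exchanges one heteroaryl ring for another and lies within the scatter, so it says little about replacing a plain phenyl by a ring bearing hetero atoms. The direction of any step in this assay is therefore uncertain; a modest rise is expected, since the heteroaryl-bearing compounds 2 and 3 sit higher than compound 1. Compound 4 is estimated at 15%, with a range from 0% to 40%, which means an expected step of a number 12.2 percentage points higher from compound 1 to compound 4 (beyond the scatter).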

Compound 4, a percentage reported as inhibition, at one concentration (the size of the read-out at that concentration, not a potency): 27.6%
Compound 4: middle estimate off by 12.6 percentage points, on the low side; low and high end bracket the measured number.
By their numbers in this assay, from the lowest: compound 1; then compounds 4, 3 and 2 (each within the scatter of the next).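

In this assay, within the data shown here, putting 1-acetyl-1H-pyrazol-3-yl in place of phenyl gives a number 24.8 percentage points higher from compound 1 to compound 4 (beyond the scatter), the first single-change comparison at this place, on an aromatic carbon meta to a large group. Among these compounds, compound 1 had no single-change neighbour among the earlier compounds, so only now can a rise be tied to one exchange of groups: the phenyl is not needed at this place for the read-out at this one tested concentration, and a five-membered aromatic ring with an acetyl group can stand there instead. Nothing available explains the rise, so the data show its size and not its cause.

The compounds shown leave open whether the rise belongs to the pyrazole ring or to its acetyl group, a split that a plain 1H-pyrazol-3-yl or a 1-methyl-1H-pyrazol-3-yl would test. They also leave open how a pyridin-4-yl would read at this same place on the core of compound 1.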